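Adding an Amino Group to a Well-Tolerated Core

The source may report more compounds than this note shows. Statements on the series, on what has been measured and on what is new or still open speak of the compounds shown alone.

Compound 2 `COc1ccc(-c2nc3cc(C(F)(F)F)ccc3[nH]2)cc1` carries a methoxy group on the outer ring of the shared core. In an ADME assay on MDBK cells (Bos taurus) for cytotoxicity, read by MTT assay, with a stated time of 96 h (a higher number here means that more compound is tolerated, a lower number that less compound is tolerated), compound 2 gives > 100000 nM, which is a limit of the assay and not a number. Compound 1 `O=C(O)CCC(=O)Nc1ccc(-c2nc3cc(C(F)(F)F)ccc3[nH]2)cc1` differs from compound 2 only in the group on that outer ring. In this assay compound 1 gives > 100000 nM, again a limit rather than a measured number. The step that the two limits leave unreadable from compound 1 to compound 2 therefore cannot be read in size, because of the limit of > 100000 nM in this assay, at which 2 of the 2 values shown sit. Compound 3 `COc1ccc(-c2nc3cc(C(F)(F)F)ccc3[nH]2)c(N)c1` has not been measured yet; it differs from compound 2 by amino in place of hydrogen on an aromatic carbon. Among the measured compounds shown here, no measured step bears on this particular change, and the one step that is known is itself unreadable, so there is no basis for expecting a move in either direction beyond the scatter. Compound 3 is therefore expected to sit at the same limit, with an expected step of a number no higher from compound 2 to compound 3 (the limit leaves the size open) of no real size. The estimate for compound 3 is 100000 nM, within a range from 30000 nM to 300000 nM, most likely reported again only as a limit.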

Compound 3, half-maximal cytotoxic concentration: 4000 nM
Estimate against measurement, compound 3: 25-fold (1.40 log units) above; the whole stated range lies above it.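

In this assay, amino in place of hydrogen on an aromatic carbon, ortho to a large group and meta to a methoxy group, brings an at least 25-fold lower number from compound 2 to compound 3 (1.39 log units; beyond the scatter). This shows that the carbon is not indifferent to substitution: with one added heavy atom, compound 3 gives a measured number, 4000 nM, which neither earlier compound gave. The full size of the step remains unknown because its starting value is a limit and not a number: the limit of > 100000 nM in this assay, at which 2 of the 3 values shown sit.

The compounds shown leave open whether this drop in tolerated concentration belongs to the amino group itself or would also follow from another group on the same carbon, such as a hydroxyl group, a methyl group or a fluorine atom. They also leave open whether the amino group must remain free, since an acetylamino group or a methylamino group on that carbon could give a different reading in this assay.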